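The source may report more compounds than this note shows. Statements on the series, on what has been measured and on what is new or still open speak of the compounds shown alone.

Measured so far:
- compound 1, `CN1C[C@H](C(=O)Nc2ccccc2)[C@@H](c2ccc(/C=C/C(=O)Nc3ccccc3N)cc2)C1`, gives 67 mL/min/kg in an in vitro ADME assay on microsomes from liver (Mus musculus) for pharmacokinetics, read by LC-MS, with a stated time of 10 min, tested at 1 uM; on this read-out higher numbers stand for fast clearance and lower numbers for slow clearance
- compound 2, `Cc1cccc(NC(=O)[C@H]2CN(C)C[C@@H]2c2ccc(/C=C/C(=O)Nc3ccccc3N)cc2)c1`, gives 74 mL/min/kg
- compound 3, `CN1C[C@H](C(=O)NC2CC2)[C@@H](c2ccc(/C=C/C(=O)Nc3ccccc3N)cc2)C1`, gives 7 mL/min/kg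

Compound 2 holds the highest of the three numbers, but its gap to compound 1 is small: a 1.1-fold higher number from compound 1 to compound 2 (0.04 log units; within the scatter). Compound 3 stands far from both of them.

Compound 4, `CN1C[C@H](C(=O)N2CCCCC2)[C@@H](c2ccc(/C=C/C(=O)Nc3ccccc3N)cc2)C1`, is compound 2 with one change: piperidin-1-yl in place of (3-methylphenyl)amino on a carbonyl carbon. The measured steps that bear on this both swap the aromatic group on the amide for a small saturated one: a 9.6-fold lower number from compound 1 to compound 3 (0.98 log units; beyond the scatter) and an 11-fold lower number from compound 2 to compound 3 (1.02 log units; beyond the scatter). Compound 4 also loses the aromatic group at that position, yet piperidin-1-yl is not cyclopropylamino, so the step is expected to point the same way without being fully as large.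

The estimate for compound 4 is therefore a drop in clearance, a 3.0-fold lower number from compound 2 to compound 4 (0.47 log units; beyond the scatter), to about 25 mL/min/kg, with a likely range from 8 mL/min/kg to 70 mL/min/kg.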

Compound 4, clearance: 42 mL/min/kg
For compound 4 the middle estimate is 1.7-fold (0.23 log units) below the measured one; the measured number falls inside the stated range.
By their numbers in this assay, from the lowest: compound 3; then compounds 4, 1 and 2 (each within the scatter of the next).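

In this assay a saturated ring on this carbonyl carbon does not by itself go with slow clearance: compound 3 and compound 4 both lack the aromatic ring, yet the change from cyclopropylamino to piperidin-1-yl gives a 6.0-fold higher number from compound 3 to compound 4 (0.78 log units; beyond the scatter) in this series. Piperidin-1-yl instead stays level with the aromatic groups, as a 1.8-fold lower number from compound 2 to compound 4 (0.25 log units; within the scatter) and a 1.6-fold lower number from compound 1 to compound 4 (0.20 log units; within the scatter) show. Compound 4 therefore goes against the simple reading of the first three compounds, and among these four the slow clearance belongs to compound 3 alone.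

No measurement shown here accounts for these differences. Still open, going by these compounds, is which feature of cyclopropylamino goes with the low number, and pyrrolidin-1-yl, morpholin-4-yl or an N-methylcyclopropylamino group on the same carbonyl carbon would test this further.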